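The source may report more compounds than this note shows. Statements on the series, on what has been measured and on what is new or still open speak of the compounds shown alone.

Among the measured compounds shown here, in a functional assay on HT-29 cells (Homo sapiens) for antiproliferative activity, read by sulforhodamine B assay, with a stated time of 72 h (on this read-out higher numbers stand for weaker inhibition and lower numbers for stronger inhibition), compound 2 `S=C(N/N=C/c1ccc2ccccc2n1)Nc1ccccc1` gives 17000 nM, the only actual number so far. Compound 1 `Cc1cccc(NC(=S)N/N=C/c2ccc3ccccc3n2)c1` stands at > 100000 nM, which is a limit of the assay. Compound 3 `COc1ccc(NC(=S)N/N=C/c2ccc3ccccc3n2)cc1` differs from compound 2 by methoxy in place of hydrogen on an aromatic carbon. For the measured compounds named here, the only measured step bearing on this is an at least 5.8-fold lower number from compound 1 to compound 2 (0.76 log units; beyond the scatter), where a different group was involved, so it is a loose guide pointing to a modest rise in this assay. The expected change is a 1.8-fold higher number from compound 2 to compound 3 (0.25 log units; within the scatter). Compound 3 is estimated at 30000 nM, within an expected range of 7000 nM to 100000 nM.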

Compound 3, half-maximal inhibitory concentration: 82300 nM
Compound 3: middle estimate off by 2.7-fold (0.44 log units), on the low side, and the stated range covers the measured number.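

In this assay, methoxy in place of hydrogen on an aromatic carbon gives a 4.8-fold higher number from compound 2 to compound 3 (0.68 log units; beyond the scatter), a modest step. Among the compounds shown here, this is the first step here with actual numbers at both ends, and it shows that methoxy para to a large group weakens inhibition; the earlier step rested on a limit and concerned a different group. For 4-methoxyphenyl in place of 3-methylphenyl on an amide-type nitrogen, the data give an at least 1.2-fold lower number from compound 1 to compound 3 (0.08 log units; that floor lies within the scatter), which sets no order between the two compounds. Compound 1 stands at a limit: the limit of > 100000 nM in this assay, at which 1 of the 3 values shown sits.

On these data alone, whether a smaller group such as fluorine, or an amine, at this same place would also raise the number stays open. So does whether hydroxyl would behave like methoxy there.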